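Amide aryl swap in a weak antiproliferative series

This account rests on a few compounds, and the source may have more. Where it says the series, first, only, none or still open, it means among the compounds named here.

Measured compounds:
compound 1 `O=C(Nc1ccc(Cl)c(-c2nnc3c(Cl)cccn23)c1)c1ccccn1` – 92000 nM
compound 2 `O=C(Nc1ccc(Cl)c(-c2nnc3c(Cl)cccn23)c1)c1ccc(Cl)cc1` – > 100000 nM (a limit of the assay, not a number)

Among the compounds with values here, in a functional assay on MDA-MB-231 cells (Homo sapiens) for antiproliferative activity, read by MTT assay, with stated times of 72 h and 4 h (a higher number here means a weaker inhibitor, a lower number a stronger inhibitor), compound 1 gives 92000 nM, the only numerical value in the set. Compound 2 reaches only the assay limit, > 100000 nM. The step of an at least 1.0-fold higher number from compound 1 to compound 2 (0.03 log units; that floor lies within the scatter) therefore cannot be sized beyond its floor, and its end point is the limit of > 100000 nM in this assay, at which 1 of the 2 values shown sits.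

Compound 3 `O=C(Nc1ccc(Cl)c(-c2nnc3c(Cl)cccn23)c1)c1ccccc1` carries phenyl in place of pyridin-2-yl on a carbonyl carbon. Within the data shown here, the only measured step that bears on this change is an at least 1.0-fold higher number from compound 1 to compound 2 (0.03 log units; that floor lies within the scatter), which likewise exchanges pyridin-2-yl on the carbonyl carbon for a six-membered aromatic ring of carbon only and runs up to the limit. That step gives no sign of a lower number in this assay and leaves open a higher one.

Compound 3 is therefore expected to show no step beyond the scatter, or a modest move toward a higher number, in this assay. Compound 3 is estimated at 120000 nM, with a range from 50000 nM to 300000 nM. The expected step is a 1.3-fold higher number from compound 1 to compound 3 (0.12 log units; within the scatter), with a real chance that only a limit is reported.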

Compound 3, half-maximal inhibitory concentration: 58200 nM
Beside the measured number, compound 3's estimate is 2.1-fold (0.31 log units) above it; the range from low to high includes it.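

In this assay, the step for phenyl in place of pyridin-2-yl on a carbonyl carbon is a 1.6-fold lower number from compound 1 to compound 3 (0.20 log units; within the scatter), so this exchange alone does not separate compound 1 from compound 3, and the ring nitrogen of pyridin-2-yl shows no measurable role at this position. Hydrogen in place of chloro on an aromatic carbon of the benzoyl group can now also be read, as an at least 1.7-fold lower number from compound 2 to compound 3 (0.23 log units; that floor lies within the scatter), which likewise shows no step beyond the scatter on its floor. The true size of that step stays unknown because compound 2 stands at a limit of the assay, not a number: the limit of > 100000 nM in this assay, at which 1 of the 3 values shown sits.

Every compound shown keeps a six-membered aromatic ring on the carbonyl carbon, so the effect of an amine, a carboxylic acid or a longer alkyl chain at this place remains open. Also open, as far as these compounds go, is whether a methoxy group in place of the chloro on the benzoyl ring would give a reading distinct from compound 3, and whether any change here can move this series beyond the scatter.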